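What a carbonyl might do to compound 3

The source may hold more compounds than are shown below. What is called first, only, known or untested is meant among the compounds shown, and "the series" means these compounds.

Compound 1 `O=C(NNc1ccccc1F)c1cccc(NS(=O)(=O)c2cnc(O)nc2O)c1`: 17000 nM
Compound 2 `O=C(NNc1ccccc1Cl)c1ccccc1NS(=O)(=O)c1cnc(O)nc1O`: 14100 nM
Compound 3 `O=C(NNc1ccc(F)cc1)c1ccccc1NS(=O)(=O)c1cnc(O)nc1O`: > 20000 nM (a limit, not a number)

These values come from a functional assay on OVCAR-3 cells (Homo sapiens) for antiproliferative activity, read by MTT assay, with a stated time of 24 h; a higher number here means a weaker inhibitor, a lower number a stronger inhibitor. Compound 3 has no exact number: it stands at the limit of > 20000 nM in this assay, at which 1 of the 3 values shown sits.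

Compound 4 `O=C(NNC(=O)c1ccccc1NS(=O)(=O)c1cnc(O)nc1O)c1ccc(F)cc1` keeps the core of compound 3 and changes one group: (4-fluorophenyl)carbonyl in place of 4-fluorophenyl on an amine nitrogen. In words, (4-fluorophenyl)carbonyl comes in place of 4-fluorophenyl on an amine nitrogen.

For the measured compounds named here, only one measured step bears on this place. It is an at least 1.4-fold higher number from compound 2 to compound 3 (0.15 log units; that floor lies within the scatter), where 4-fluorophenyl came in place of 2-chlorophenyl on an amine nitrogen. Going by the values given here, that step involved no added carbonyl, so it is only a weak guide, and no measured step shows what a carbonyl does here. The series therefore offers no ground for expecting a large move in either direction, and no step beyond the scatter is expected in this assay. The expected step is an at least 1.1-fold lower number from compound 3 to compound 4 (0.04 log units; that floor lies within the scatter). Compound 4 is expected to stay in the weak range seen for compound 2 at 14100 nM. For compound 4 the estimated value is 18000 nM, with an expected range from 7000 nM to 40000 nM. A result given only as a limit would also be no surprise.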

Compound 4, half-maximal inhibitory concentration: 15100 nM
Estimate against measurement, compound 4: 1.2-fold (0.08 log units) above; low and high end bracket the measured number.
By their numbers in this assay, from the lowest: compounds 2, 4 and 1 (each within the scatter of the next). At a limit, above all of these: compound 3.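

Adding a carbonyl at this amine nitrogen, whose other neighbour is an amide-type nitrogen, gives in this assay a first direct reading of this change: an at least 1.3-fold lower number from compound 3 to compound 4 (0.12 log units; that floor lies within the scatter) and so shows no shift beyond the scatter, though it does not exclude one. Against the 2-chlorophenyl group at the same place, the (4-fluorophenyl)carbonyl group gives a 1.1-fold higher number from compound 2 to compound 4 (0.03 log units; within the scatter) and the two groups cannot be told apart in this assay, so this nitrogen carries the added carbonyl with no loss beyond the scatter from compound 2. Compound 3 itself is held at a limit of the assay and not at a number: the limit of > 20000 nM in this assay, at which 1 of the 4 values shown sits.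

Going by these compounds, with no exact value for compound 3, the true size of the carbonyl step remains unknown, and it could yet prove larger than its printed floor. The compounds shown also leave open how this nitrogen would respond to other groups, such as a small acetyl group or a benzoyl group carrying a carboxylic acid, and whether a (2-chlorophenyl)carbonyl group would read the same as the (4-fluorophenyl)carbonyl group.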